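The compounds below may be only part of what the source reports. "The series", "measured", "known", "first", "only" and "open" are said of these compounds alone.

Measured so far:
Compound 1 `CC(C)(C)n1ncc(OCc2nnc(-c3ccccc3Cl)o2)c(Cl)c1=O`: 61.2 ug/mL
Compound 2 `CC(C)(C)n1ncc(OCc2nnc(-c3cc(F)c(Cl)c([N+](=O)[O-])c3Cl)o2)c(Cl)c1=O`: > 300 ug/mL, a limit of the assay and not a number
Compound 3 `CCn1ncc(OCc2nnc(-c3ccc(F)cc3)o2)c(Cl)c1=O`: > 300 ug/mL, a limit of the assay and not a number
Not yet measured:
Compound 4 `CC(C)(C)n1ncc(OCc2nnc(-c3ccc(Cl)cc3)o2)c(Cl)c1=O`

All of these readings come from a functional assay on the whole organism for inhibition, with Mythimna separata as the target, with a stated time of 5 days; on this read-out lower numbers stand for an effect already at smaller amounts and higher numbers for an effect only at larger amounts of compound. In this assay, among the compounds with values here, compound 1 gives 61.2 ug/mL, and it is the only compound here with a true number. The remaining readings are limits, as the limit of > 300 ug/mL in this assay, at which 2 of the 3 values shown sit, makes plain, so compound 1 has no measured neighbour to be compared with number against number.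

Compound 4 keeps the shared core of compound 1 and changes one thing: 4-chlorophenyl stands in place of 2-chlorophenyl on an aromatic carbon (4-chlorophenyl in place of 2-chlorophenyl on an aromatic carbon). The two compounds have the same atoms, joined differently.

Within the data shown here, no measured pair isolates this kind of change, so any forecast is rough. The two limit readings make a move toward larger amounts seem more likely than a move toward smaller ones, and a reading at the limit remains possible. The expected change is modest in size, estimated as a 1.6-fold higher number from compound 1 to compound 4 (0.21 log units; within the scatter). For compound 4 the estimated value is 100 ug/mL, with an expected range from 30 ug/mL to 300 ug/mL.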

Compound 4, half-maximal effective concentration: 1.9 ug/mL
For compound 4 the middle estimate is 53-fold (1.72 log units) above the measured one; measured number outside the range, below it.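

In this assay, placing the chlorine differently on the phenyl group gives a 32-fold lower number from compound 1 to compound 4 (1.51 log units; beyond the scatter), a step well beyond the usual scatter. Compound 1 and compound 4 have the same atoms, and 2-chlorophenyl and 4-chlorophenyl match in every count given for them, so this read-out responds to how the atoms are joined and not only to which atoms are present. The earlier compounds shown here could not show this, since they offered one true number and no pair differing in one place; the aryl group on the carbon of the five-membered aromatic ring that lies next to the ring nitrogen and the ring oxygen now stands out as a place where a single change can matter greatly.

This single step does not tell whether a methoxy group or a nitrile in place of the chlorine of 4-chlorophenyl would keep such a low number, or whether the gain belongs to chlorine alone. The remaining compounds cannot settle this, as their readings are limits and not numbers, so no further steps can be read: the limit of > 300 ug/mL in this assay, at which 2 of the 4 values shown sit.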